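The compounds below may be only part of what the source reports. "The series", "measured", "known", "first", "only" and "open" are said of these compounds alone.

In a functional assay on SK-OV-3 cells (Homo sapiens) for cytotoxicity, read by MTT assay, with a stated time of 3 days (a higher number here means a weaker inhibitor, a lower number a stronger inhibitor), compound 1 `N#Cc1c(O)nc(SCc2nc3ccccc3[nH]2)nc1-c1ccccc1` gives 2.55 nM, compound 2 `N#Cc1c(NN)nc(SCc2nc3ccccc3[nH]2)nc1-c1ccccc1` gives 2.7 nM, and compound 3 `CCNc1nc(SCc2nc3ccccc3[nH]2)nc(-c2ccccc2)c1C#N` gives 7.35 nM, the highest number of the three and so the weakest result. Compound 4 `N#Cc1c(Nc2nccs2)nc(SCc2nc3ccccc3[nH]2)nc1-c1ccccc1` differs from compound 3 in one place: 1,3-thiazol-2-yl in place of ethyl on a nitrogen on an aromatic ring. In other words, 1,3-thiazol-2-yl stands in place of ethyl on a nitrogen on an aromatic ring. Three measured changes bear on this place: a 1.1-fold higher number from compound 1 to compound 2 (0.02 log units; within the scatter), a 2.9-fold higher number from compound 1 to compound 3 (0.46 log units; beyond the scatter) and a 2.7-fold higher number from compound 2 to compound 3 (0.43 log units; beyond the scatter). All are small, but none brings in a ring, so they are only a loose guide. A small move toward a lower number is therefore expected, namely a 1.5-fold lower number from compound 3 to compound 4 (0.17 log units; within the scatter). Compound 4 is estimated at 5 nM, within a range of 1.5 nM to 16 nM.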

Compound 4, half-maximal inhibitory concentration: 5.81 nM
The estimate for compound 4 lay 1.2-fold (0.07 log units) below the measured number; low and high end bracket the measured number.
By their numbers in this assay, from the lowest: compounds 1 and 2 (each within the scatter of the next); then compounds 4 and 3 (each within the scatter of the next).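

Placing 1,3-thiazol-2-yl on this nitrogen gives a 1.3-fold lower number from compound 3 to compound 4 (0.10 log units; within the scatter) in this assay so this five-membered aromatic ring does about as well here as ethyl. Compared with the aminoamino and hydroxy compounds, both a 2.2-fold higher number from compound 2 to compound 4 (0.33 log units; beyond the scatter) and a 2.3-fold higher number from compound 1 to compound 4 (0.36 log units; beyond the scatter) are modest steps, so adding a ring does not set compound 4 far apart from them. Nothing available explains these steps.

Still open, going by these compounds, is how a phenyl or benzyl group on this nitrogen would behave. The same goes for a longer chain such as butyl.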